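Ortho Substituent Swap on the Benzylamide Core

A few compounds are considered here, and "the series" means these few. Any claim that something is new, unique, unknown or untested is made for them only; others in the source may bear on it.

Measured so far:
compound 1 `Cc1ccc(N2CCN(c3cc(C(F)(F)F)ccc3CNC(=O)C(C)c3ccc(NS(C)(=O)=O)c(F)c3)CC2)cc1` — 0.7 nM
compound 2 `COc1ccc(N2CCN(c3cc(C(F)(F)F)ccc3CNC(=O)C(C)c3ccc(NS(C)(=O)=O)c(F)c3)CC2)cc1` — 1.6 nM
compound 3 `CCCOc1cc(C(F)(F)F)ccc1CNC(=O)C(C)c1ccc(NS(C)(=O)=O)c(F)c1` — 2 nM

In an assay on CHO cells for antagonist activity at transient receptor potential cation channel subfamily V member 1 (Homo sapiens), read by FLIPR (a lower number here means a stronger inhibitor, a higher number a weaker inhibitor), compound 3 gives the highest number of the three, though the gap to compound 2 is within the scatter; only the gap to compound 1 lies beyond it. Among the compounds with values here, the one measured step, a 2.3-fold higher number from compound 1 to compound 2 (0.36 log units; beyond the scatter), sits on a different part of the molecule and is modest. Compound 4 `CC(C(=O)NCc1ccc(C(F)(F)F)cc1F)c1ccc(NS(C)(=O)=O)c(F)c1` carries a change without any measured counterpart here: fluoro in place of propoxy on an aromatic carbon. Replacing a chain of that size by a single atom is a larger change than anything measured, so a step beyond the scatter toward a higher number is expected, a 5.0-fold higher number from compound 3 to compound 4 (0.70 log units; beyond the scatter). For compound 4 the estimate is 10 nM, within 2 nM to 50 nM.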

Compound 4, inhibition constant: 68.7 nM
Beside the measured number, compound 4's estimate is 6.9-fold (0.84 log units) below it, outside the stated range (above it).
By their numbers in this assay, from the lowest: compound 1; then compounds 2 and 3 (each within the scatter of the next); then compound 4.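

In this assay, the aromatic carbon ortho to a large group proves sensitive to its substituent: fluoro in place of propoxy gives a 34-fold higher number from compound 3 to compound 4 (1.54 log units; beyond the scatter), a large step set against the modest 2.3-fold higher number from compound 1 to compound 2 (0.36 log units; beyond the scatter) made elsewhere on the molecule. At this position, a single fluorine atom does not match the propoxy chain. No evidence here bears on the reason for this step. The compounds shown leave open whether the number follows chain length or depends on the oxygen atom of the chain. Ethoxy or butoxy at this position would bear on that question.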